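The source may hold more compounds than are shown below. What is called first, only, known or untested is meant among the compounds shown, and "the series" means these compounds.

Compound 1 `Cc1ccc(CNC(=O)c2nc(C(C)(C)NC(=O)OCc3ccccc3)nc(O)c2O)cc1`: 234000 nM
Compound 2 `CC(C)(NC(=O)OCc1ccccc1)c1nc(O)c(O)c(NC(=O)NCc2ccc(F)cc2)n1`: 81100 nM

Both numbers come from an ADME assay on C8166 cells (Homo sapiens) for cytotoxicity, read by MTT assay, with a stated time of 3 days; on this read-out higher numbers stand for lower toxicity in this test and lower numbers for higher toxicity in this test. Going by the values given here, of the two values shown, compound 1 gives the higher one and compound 2 gives the lower one; the gap between them lies beyond the usual scatter of this test, so compound 1 is the less toxic of the two compounds measured so far. Compound 3 `CC(C)(NC(=O)OCc1ccccc1)c1nc(O)c(O)c(C(=O)NCc2ccc(C(F)(F)F)cc2)n1` has not been measured yet. It is built from compound 1 by a single change: trifluoromethyl in place of methyl on an aromatic carbon. Among the compounds with values here, no pair of measured compounds shows how this exchange alone plays out in this assay, as compound 2 differs from compound 1 in more than one place. With only the two numbers shown to go on, the most likely outcome for compound 3 is a change in this assay of no more than the scatter, with a slight lean toward a lower number. The step that this expectation means is a 1.5-fold lower number from compound 1 to compound 3 (0.17 log units; within the scatter). Compound 3 is accordingly estimated at 160000 nM, with a range from 60000 nM to 350000 nM.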

Compound 3, half-maximal cytotoxic concentration: 58100 nM
For compound 3 the middle estimate is 2.8-fold (0.44 log units) above the measured one; measured number below the stated range.
By their numbers in this assay, from the lowest: compounds 3 and 2 (each within the scatter of the next); then compound 1.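

In this assay, putting trifluoromethyl in place of methyl on an aromatic carbon, para to a large group, gives a 4.0-fold lower number from compound 1 to compound 3 (0.61 log units; beyond the scatter), a shift toward higher toxicity in this test. This shows that this position on the ring is not indifferent to what sits there: one exchange at a single site, with the rest of the molecule untouched, moves the number beyond the usual scatter, something compounds 1 and 2 could not show since they differ in more than one place. Nothing measured here explains why the exchange has this effect, so the step stands as an observation without a known cause.

Going by these compounds, what remains open is how other groups at this same position would behave, such as a chlorine atom, a methoxy group or an amine, and so whether the number falls steadily across a series of groups or trifluoromethyl is a special case. This is also a single pair, so it leaves open whether the same exchange would give a similar step on a different core, such as the one carrying the urea link in compound 2.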